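The source may hold more compounds than are shown below. What is called first, only, known or untested is meant among the compounds shown, and "the series" means these compounds.

Compounds measured so far:
compound 1 `CC(=O)N1CCc2nc(C#Cc3ccccc3)sc2C1`, 90 nM
compound 2 `COC1CC(C(=O)N2CCc3nc(C#Cc4ccccc4)sc3C2)C1`, > 10000 nM

In an assay on HEK293 cells for negative allosteric modulation of metabotropic glutamate receptor 5 (Homo sapiens), read by FLIPR, with a stated time of 1 h (on this read-out lower numbers stand for stronger inhibition and higher numbers for weaker inhibition), compound 1 gives 90 nM. For compound 2 this assay reports only a limit, > 10000 nM, so its true place is not pinned to a number (the limit of > 10000 nM in this assay, at which 1 of the 2 values shown sits). Among the compounds with values here, the single measured step, an at least 110-fold higher number from compound 1 to compound 2 (2.04 log units; beyond the scatter), shows that exchanging the small methyl on the carbonyl carbon for a ring-bearing group moved the read-out far beyond the scatter, toward weaker inhibition.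

Compound 3 `CC1CCC(C(=O)N2CCc3nc(C#Cc4ccccc4)sc3C2)CC1` keeps the shared core and the amide, but carries a different ring on the carbonyl carbon: 4-methylcyclohexyl in place of 3-methoxycyclobutyl on a carbonyl carbon. Within the data shown here, the only guidance comes from that one step, which concerns a different ring entering the same place; no measured pair shows what a six-membered ring of carbon only does there. With compound 2 already sitting at the limit of this assay, the step of an at least 1.6-fold lower number from compound 2 to compound 3 (0.22 log units; that floor lies within the scatter) is expected to stay within the scatter or bring at most a modest return toward stronger inhibition. Compound 3 is therefore estimated at 6000 nM, with a range from 600 nM to 30000 nM.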

Compound 3, half-maximal inhibitory concentration: > 10000 nM
Compound 3: no number, only a limit (the forecaster's own chance of this, stated with the estimate: 55%); middle value at least 1.6-fold (0.22 log units) away from the limit.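

In this assay compound 3 gives > 10000 nM, which is a limit and not a number. The change from methyl, an at least 110-fold higher number from compound 1 to compound 3 (2.04 log units; beyond the scatter), shows that the large shift toward weaker inhibition is not confined to 3-methoxycyclobutyl: 4-methylcyclohexyl, a ring of carbon only with no hydrogen-bond acceptor, on the same carbonyl carbon gives a shift beyond the scatter as well. The step linking compound 2 and compound 3 cannot be read, so these two rings cannot be ranked against each other, and both compounds stop at the same end of the scale: the limit of > 10000 nM in this assay, at which 2 of the 3 values shown sit.

Methyl is still the only group here on the carbonyl carbon that gives a number, so it remains open whether a slightly larger group, such as ethyl or cyclopropyl, would keep a measurable value in this assay. Going by these compounds, it is equally open whether a group of another kind in this place, such as a phenyl ring or a short chain ending in an amine, would bring the read-out back toward stronger inhibition.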